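This account rests on a few compounds, and the source may have more. Where it says the series, first, only, none or still open, it means among the compounds named here.

Compounds 1, 2 and 3 share one core and differ only in the group attached to a single aromatic carbon of it. Compound 1 `CCOC(=O)c1cnc(SC)nc1NN1C(=O)C=C(C)C1=O` carries methylsulfanyl there, and in a functional assay on Jurkat cells for inhibition of nuclear factor NF-kappa-B complex (Homo sapiens) (a higher number here means a weaker inhibitor, a lower number a stronger inhibitor), compound 1 gives 200 nM. Compound 3 `CCOC(=O)c1cnc(C2CC2)nc1NN1C(=O)C=C(C)C1=O` carries cyclopropyl, and in this assay compound 3 gives 1000 nM. Compound 2 `CCOC(=O)c1cnc(-c2cnc3ccccc3c2)nc1NN1C(=O)C=C(C)C1=O` carries quinolin-3-yl; in this assay compound 2 gives 6000 nM, the highest of the three numbers, so it is the weakest inhibitor measured. The steps were a 30-fold higher number from compound 1 to compound 2 (1.48 log units; beyond the scatter), a 5.0-fold higher number from compound 1 to compound 3 (0.70 log units; beyond the scatter) and a 6.0-fold lower number from compound 2 to compound 3 (0.78 log units; beyond the scatter).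

Compound 4 `CCOC(=O)c1cnc(Sc2ccccc2)nc1NN1C(=O)C=C(C)C1=O` has not been measured. It differs from compound 2 thus: phenylsulfanyl in place of quinolin-3-yl on an aromatic carbon. The entering group is smaller than quinolin-3-yl and, like methylsulfanyl in compound 1, contains one sulfur, but it keeps an aromatic ring. Because a 30-fold higher number from compound 1 to compound 2 (1.48 log units; beyond the scatter) and a 6.0-fold lower number from compound 2 to compound 3 (0.78 log units; beyond the scatter) both show that a smaller group than quinolin-3-yl gives a lower number, a decrease is expected, though only part of the way back to compound 1. In this assay compound 4 is estimated at 1000 nM, with a likely range from 250 nM to 4000 nM, which means an expected step of a 6.0-fold lower number from compound 2 to compound 4 (0.78 log units; beyond the scatter).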

Compound 4, half-maximal inhibitory concentration: 1000 nM
For compound 4 middle estimate and measured number coincide at the digits printed; low and high end bracket the measured number.
By their numbers in this assay, from the lowest: compound 1; then compounds 3 and 4 (each within the scatter of the next); then compound 2.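

Keeping the sulfur at this position does not by itself preserve the number of compound 1, since changing only the group on that sulfur, phenyl in place of methyl, gives a 5.0-fold higher number from compound 1 to compound 4 (0.70 log units; beyond the scatter) in this assay. An aromatic ring is also compatible with a lower number than quinolin-3-yl gives: phenylsulfanyl produces a 6.0-fold lower number from compound 2 to compound 4 (0.78 log units; beyond the scatter), while the comparison with cyclopropyl shows no change at the digits printed from compound 3 to compound 4 (within the scatter), so these two groups cannot be told apart here. No measurement shown explains these differences.

The compounds shown leave open whether an ethyl or benzyl group on the sulfur would give a number closer to compound 1 or to compound 4. They also leave open how a methoxy group or a dimethylamino group at this position would compare with methylsulfanyl.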